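The source may hold more compounds than are shown below. What is called first, only, known or untested is meant among the compounds shown, and "the series" means these compounds.

Measured so far:
Compound 1 `Cc1cc(C)c(-n2c(Cl)cn3c(CN(C)Cc4ccccc4)c(C(F)(F)F)nc23)c(C)c1`: 160 nM
Compound 2 `Cc1cc(C)c(-n2c(Cl)cn3c(CN4CCCC4c4ccccc4)c(C(F)(F)F)nc23)c(C)c1`: > 7000 nM

In an assay on cells for displacement of a labelled ligand from corticotropin-releasing factor receptor 1 (Homo sapiens), with a stated time of 100 min (a lower number here means a stronger inhibitor, a higher number a weaker inhibitor), compound 1 gives 160 nM. For compound 2 only a limit is known, > 7000 nM, namely (the limit of > 7000 nM in this assay, at which 1 of the 2 values shown sits). For the measured compounds named here, the one measured step is an at least 43-fold higher number from compound 1 to compound 2 (1.64 log units; beyond the scatter). Compound 3 `Cc1cc(C)c(-n2c(Cl)cn3c(CN4CCCC4Cc4ccccc4)c(C(F)(F)F)nc23)c(C)c1` differs from compound 2 by benzyl in place of phenyl on a saturated ring carbon, restoring the benzyl of compound 1 while keeping the ring of compound 2. Going by the values given here, only the step from compound 1 to compound 2 bears on this, and it does not separate the ring from the benzyl. Compound 3 is expected near 3000 nM, from 500 nM to 10000 nM. The expected step is an at least 2.3-fold lower number from compound 2 to compound 3 (0.36 log units; beyond the scatter), a modest gain at best.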

Compound 3, inhibition constant: 190 nM
Estimate against measurement, compound 3: 16-fold (1.20 log units) above, outside the stated range (below it).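

On a saturated ring carbon next to the ring nitrogen, benzyl in place of phenyl gives an at least 36-fold lower number from compound 2 to compound 3 (1.56 log units; beyond the scatter), so the five-membered ring alone does not carry the loss seen for compound 2. Compound 3 gives 190 nM in the same range as compound 1 at 160 nM, so the ring is tolerated when it bears benzyl. Going by these compounds, the true size of the step is unknown because compound 2 stands at a limit of the assay: the limit of > 7000 nM in this assay, at which 1 of the 3 values shown sits.

On these data alone, whether a longer chain such as phenethyl holds this binding stays open. So does the effect of an amine or a carboxylic acid on the benzyl ring.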